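Adding an Ethyl Group at Two Points on an Amine Chain

This account rests on a few compounds, and the source may have more. Where it says the series, first, only, none or still open, it means among the compounds named here.

Compound 1 `CCC(CC)Nc1nc(C)nc2c1nnn2-c1c(C)cc(C)cc1C` carries a short branched chain on an amine attached to its core. In an in vitro assay on 293-EBNA cells for binding affinity to corticotropin-releasing factor receptor 1 (Homo sapiens) (a lower number here means a stronger inhibitor, a higher number a weaker inhibitor), compound 1 gives 5.7 nM. Compound 2 `CCCCC(CC)Nc1nc(C)nc2c1nnn2-c1c(C)cc(C)cc1C` differs from it by ethyl in place of hydrogen on a saturated chain carbon, three bonds along the chain from a nitrogen on an aromatic ring, and in this assay compound 2 gives 7.6 nM, a step of a 1.3-fold higher number from compound 1 to compound 2 (0.12 log units; within the scatter). Compound 3 `CCCCN(CC)c1nc(C)nc2c1ncn2-c1ccc(C(C)C)cc1Br` is built on a different core; the difference between the two cores is not broken down here. In this assay compound 3 gives 4.3 nM, and this value and those of compound 1 and compound 2 lie within the scatter of each other. Compound 4 `CCCCN(CCCC)c1nc(C)nc2c1ncn2-c1ccc(C(C)C)cc1Br` is the not yet measured partner of compound 3, differing from it by ethyl in place of hydrogen on a saturated chain carbon, two bonds along the chain from a nitrogen on an aromatic ring. This is the same kind of change as from compound 1 to compound 2, but the place differs: there the ethyl entered three bonds along the chain from a nitrogen on an aromatic ring, here two bonds along the chain from a nitrogen on an aromatic ring. Because a 1.3-fold higher number from compound 1 to compound 2 (0.12 log units; within the scatter) stayed within the scatter, a similarly small step is expected here, a 1.3-fold higher number from compound 3 to compound 4 (0.11 log units; within the scatter). Compound 4 is expected to give 5.5 nM, between 2.5 nM and 12 nM.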

Compound 4, inhibition constant: 6.1 nM
Compound 4: the middle estimate sits 1.1-fold (0.04 log units) below what was measured; the range from low to high includes it.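

In this assay the new step is small, a 1.4-fold higher number from compound 3 to compound 4 (0.15 log units; within the scatter), so the added ethyl makes no difference that can be told from the usual spread of repeated measurements. Set beside the earlier step, the same change gives steps of matching size on the core of compound 1 and the core of compound 3: the same change on two cores in this assay, a 1.3-fold higher number (0.12 log units; within the scatter) from compound 1 to compound 2 and a 1.4-fold higher number (0.15 log units; within the scatter) from compound 3 to compound 4, 1.1-fold (0.03 log units) apart, within the scatter of two such steps This shows agreement between only two pairs, with the ethyl three bonds along the chain from a nitrogen on an aromatic ring in one pair and two bonds along in the other; neither step is large enough to show a real effect of the ethyl, and two pairs give no general rule for other cores.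

The compounds shown leave open whether a longer chain, or a chain ending in an amine or a carboxylic acid, would give a similarly small step at these places. They also leave open whether the ethyl step stays this small on any further core.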